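A Methyl Added Where Only Limits Are Known

The source may hold more compounds than are shown below. What is called first, only, known or untested is meant among the compounds shown, and "the series" means these compounds.

In an ADME assay on cells (Fibroblast, Homo sapiens) for inhibition, read by MTT assay, with a stated time of 24 h (a lower number here means a stronger inhibitor, a higher number a weaker inhibitor), compound 1 (`CCCCOc1ccc(C(=O)N/N=C/c2ccc3c(c2)no[n+]3[O-])cc1`) gives > 200000 nM as a limit of the assay and not a number. Compound 2 (`CC(C)c1ccc(C(=O)N/N=C/c2ccc3c(c2)no[n+]3[O-])cc1`) gives > 200000 nM as a limit too, so it has no exact number of its own. The two readings therefore sit at one shared limit (the limit of > 200000 nM in this assay, at which 2 of the 2 values shown sit) and cannot be ranked against each other. In compound 3 (`CC(C)(C)c1ccc(C(=O)N/N=C/c2ccc3c(c2)no[n+]3[O-])cc1`) the isopropyl of compound 2 becomes tert-butyl (methyl in place of hydrogen on a saturated chain carbon bound to an aromatic carbon and two saturated chain carbons). For the measured compounds named here, the only measured step to lean on is a step that the two limits leave unreadable from compound 1 to compound 2 and it offers no size to carry forward. For that reason no step beyond the scatter is expected in this assay in either direction, and compound 3 is expected to read at the same limit as the others. The expected change is a number no higher from compound 2 to compound 3 (the limit leaves the size open) as an estimate only. Compound 3 is estimated at 200000 nM with an expected range from 100000 nM to 400000 nM and a report of only a limit is the likeliest outcome.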

Compound 3, half-maximal inhibitory concentration: > 200000 nM
Compound 3: a limit, no number; the forecaster's own chance of this, stated with the estimate: 75%; the middle value lies on the limit itself.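

Compound 3 also gives a limit of the assay and not a number, so no step can be read among compound 1, compound 2 and compound 3: the limit of > 200000 nM in this assay, at which 3 of the 3 values shown sit. The compounds shown leave open where the true readings of all three lie in this assay, and whether butoxy, isopropyl and tert-butyl differ there at all.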